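The compounds below may be only part of what the source reports. "The series", "measured", "known", "first", "only" and "open" are said of these compounds alone.

Compound 1 `CCOC(=O)CN(Cc1ccccc1)C(=O)/C(C)=C/c1ccc(C(=O)Oc2ccc(C(=N)N)cc2)cc1` stands at the bottom of an in vitro ADME assay on a cell-free system (plasma) for pharmacokinetics; a lower number here means that the compound disappears faster, a higher number that the compound lasts longer: in this assay compound 1 gives < 0.0167 h, which is a limit and not a number. Compound 3 `C/C(=C\c1ccc(C(=O)Oc2ccc(C(=N)N)cc2)cc1)C(=O)N(CC(=O)O)Cc1ccccc1` stands at the top, and in this assay compound 3 gives > 1 h, again a limit. Compound 2 `CCOC(=O)C(C(=O)OCC)N(CCCC(=O)O)C(=O)/C(C)=C/c1ccc(C(=O)Oc2ccc(C(=N)N)cc2)cc1` gives 0.483 h in this assay. Among the compounds with values here, the one measured step, an at least 59-fold higher number from compound 1 to compound 3 (1.77 log units; beyond the scatter), changes the ester and not the amide nitrogen, and it runs between the limit of < 0.0167 h in this assay, at which 1 of the 3 values shown sits, and (the limit of > 1 h in this assay, at which 1 of the 3 values shown sits). Compound 4 `CCOC(=O)CN(C(=O)/C(C)=C/c1ccc(C(=O)Oc2ccc(C(=N)N)cc2)cc1)C1CCCCC1` differs from compound 1 by cyclohexyl in place of benzyl on an amide-type nitrogen, the ethyl ester of compound 1 staying in place. Within the data shown here, no measured step covers this change, so no shift beyond the scatter is expected. Compound 4 is therefore estimated at 0.015 h (range 0.005 h to 0.06 h), most likely once more reported as a limit. The step that the limit leaves unreadable from compound 1 to compound 4 is an expectation only.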

Compound 4, half-life: < 0.0834 h
Compound 4: a limit, no number (the forecaster's own chance of this, stated with the estimate: 60%); the middle value does not contradict the limit.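

Compound 1 and compound 4 both stand as limits in this assay, so no step can be read between them. The compounds shown leave open whether cyclohexyl in place of benzyl on an amide-type nitrogen shifts the half-life at all.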